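Sulfonyl substituent swaps: from compound 3 to compound 4

The compounds below may be only part of what the source reports. "The series", "measured", "known", "first", "only" and "open" are said of these compounds alone.

In a functional assay on A2780 cells (Homo sapiens) for cytotoxicity, read by sulforhodamine B assay, with a stated time of 72 h (a lower number here means a stronger inhibitor, a higher number a weaker inhibitor), three compounds share one core and differ only in the group on a sulfonyl sulfur. Compound 1 `CC(C)n1cc(S(=O)(=O)c2ccc(CNC(=O)N3Cc4ccncc4C3)cc2)cn1` gives 11 nM, compound 2 `O=C(NCc1ccc(S(=O)(=O)C2CCC(F)(F)CC2)cc1)N1Cc2ccncc2C1` gives 13 nM, and compound 3 `O=C(NCc1ccc(S(=O)(=O)C2CCCOC2)cc1)N1Cc2ccncc2C1` gives 32 nM. Compound 3 has the highest number of the three and is the weakest of them. The first swap stays within the scatter, at a 1.2-fold higher number from compound 1 to compound 2 (0.07 log units; within the scatter). The two swaps to oxan-3-yl are modest and lie beyond it, at a 2.9-fold higher number from compound 1 to compound 3 (0.46 log units; beyond the scatter) and a 2.5-fold higher number from compound 2 to compound 3 (0.39 log units; beyond the scatter).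

Going by the values given here, compound 4 `CCC(=O)N1CCC(S(=O)(=O)c2ccc(CNC(=O)N3Cc4ccncc4C3)cc2)CC1` has no measurement yet. The change is 1-propanoylpiperidin-4-yl in place of oxan-3-yl on a sulfonyl sulfur. Among the compounds with values here, no measured compound carries this group, so the only evidence is the three swaps at the same place, and these span a narrow range. With compound 3 at 32 nM, the top of that range, a new group is more likely to lower the number than to raise it. A modest move is expected, of a size like a 2.5-fold higher number from compound 2 to compound 3 (0.39 log units; beyond the scatter) in reverse, and the direction remains uncertain. The expected step is a 2.1-fold lower number from compound 3 to compound 4 (0.33 log units; beyond the scatter). For compound 4 the estimate is 15 nM, with an expected range of 5 nM to 45 nM.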

Compound 4, half-maximal inhibitory concentration: 54 nM
The estimate for compound 4 lay 3.6-fold (0.56 log units) below the measured number; measured number above the stated range.
By their numbers in this assay, from the lowest: compounds 1 and 2 (each within the scatter of the next); then compounds 3 and 4 (each within the scatter of the next).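

In this assay the larger 1-propanoylpiperidin-4-yl group, with 10 heavy atoms against the 6 of oxan-3-yl, leaves the number in the same band as the smaller ring, at a 1.7-fold higher number from compound 3 to compound 4 (0.23 log units; within the scatter) and so gives no separation between the two groups. Against the other two groups on the sulfonyl sulfur the distance is modest but clear, with a 4.2-fold higher number from compound 2 to compound 4 (0.62 log units; beyond the scatter) and a 4.9-fold higher number from compound 1 to compound 4 (0.69 log units; beyond the scatter) and the four compounds now falling into two pairs: 1-isopropyl-1H-pyrazol-4-yl and 4,4-difluorocyclohexyl in the lower pair, oxan-3-yl and 1-propanoylpiperidin-4-yl in the higher one, each pair within the scatter and with no compound in this small set going against the split. Nothing measured alongside these numbers bears on what lies behind this split.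

Going by these compounds, whether the propanoyl part or the piperidine ring sets the number of compound 4 stays open, and the free piperidine amine or an acetyl or butanoyl group on the same nitrogen would separate the two. On these data alone, it also stays open whether the two-pair split holds for other groups on the sulfonyl sulfur, such as a carboxylic acid on the ring or a plain phenyl ring.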